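A few compounds are considered here, and "the series" means these few. Any claim that something is new, unique, unknown or untested is made for them only; others in the source may bear on it.

Measured so far: compound 1 `C(=C1\CCCN=C1c1cccnc1)\c1ccccc1` and compound 2 `FC(F)Oc1ccc(/C=C2\CCCN=C2c2cccnc2)cc1`.

In an assay on membranes from brain for displacement of a labelled ligand from Neuronal acetylcholine receptor; alpha4/beta2 (Rattus norvegicus), with a stated time of 3 h (a higher number here means a weaker inhibitor, a lower number a stronger inhibitor), compound 1 gives 850 nM. In this assay compound 2 gives 1160 nM; the two values lie within the scatter of each other, as a 1.4-fold higher number from compound 1 to compound 2 (0.14 log units; within the scatter) shows, so neither can be ranked above the other. Compound 3 `C(=C1\CCCN=C1c1cccnc1)\c1ccc(-n2ccnn2)cc1` differs from compound 2 by 1H-1,2,3-triazol-1-yl in place of difluoromethoxy on an aromatic carbon. Among the measured compounds shown here, the only step that bears on this change is a 1.4-fold higher number from compound 1 to compound 2 (0.14 log units; within the scatter), which shows that a group on this aromatic carbon is tolerated; a step in this assay no larger than the scatter is therefore expected, in either direction. For compound 3 the expected value in this assay is 1200 nM, between 400 nM and 3600 nM, which means an expected step of a 1.0-fold higher number from compound 2 to compound 3 (0.01 log units; within the scatter).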

Compound 3, inhibition constant: 520 nM
Beside the measured number, compound 3's estimate is 2.3-fold (0.36 log units) above it; low and high end bracket the measured number.
By their numbers in this assay, from the lowest: compounds 3, 1 and 2 (each within the scatter of the next, the first and the last beyond it).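

In this assay, among the compounds shown here, 1H-1,2,3-triazol-1-yl in place of difluoromethoxy, on this aromatic carbon para to a large group, gives the first step here beyond the scatter (a 2.2-fold lower number from compound 2 to compound 3 (0.35 log units; beyond the scatter)). Set against hydrogen at the same carbon, the triazole stays within the scatter (a 1.6-fold lower number from compound 1 to compound 3 (0.21 log units; within the scatter)), so the position tolerates a five-membered aromatic ring, and only the two substituents differ from each other. Nothing given here accounts for that difference. The compounds shown leave open how an amine or a carboxylic acid would read on this carbon, and whether an isomeric triazole, joined through a carbon, would match the 1H-1,2,3-triazol-1-yl group.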